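A few compounds are considered here, and "the series" means these few. Any claim that something is new, unique, unknown or untested is made for them only; others in the source may bear on it.

Measured so far in a functional assay on PC-3 cells (Homo sapiens) for antiproliferative activity, with a stated time of 48 h; a lower number here means a stronger inhibitor, a higher number a weaker inhibitor:
- compound 1 `CCN(CC)c1ccc(-c2cccc(OC)c2)nn1`: > 25000 nM
- compound 2 `CCN(CC)c1ccc(-c2ccc(C#N)cc2)nn1`: > 25000 nM

Compound 1 reads > 25000 nM, which is a limit and not a number. Compound 2 reads > 25000 nM, which is also a limit. Compound 2 stands at the limit of > 25000 nM in this assay, at which 2 of the 2 values shown sit.

The next compound is compound 3 `CCN(CC)c1ccc(-c2ccc(C(=O)OC)cc2)nn1`, with methoxycarbonyl in place of cyano on an aromatic carbon, para to a large group: methoxycarbonyl in place of cyano on an aromatic carbon. No measured pair in the series sizes a change of this kind in this assay. With compound 2 at > 25000 nM, no shift beyond the scatter is expected in either direction. The expected change is a number no higher from compound 2 to compound 3 (the limit leaves the size open). Compound 3 is estimated at 25000 nM, with an expected range of 10000 nM to 50000 nM.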

Compound 3, half-maximal inhibitory concentration: 90 nM
Estimate against measurement, compound 3: 280-fold (2.44 log units) above; the measured number lies below the stated range.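

In this assay, the aromatic carbon para to a large group is a place where a single change separates compounds: methoxycarbonyl in place of cyano gives an at least 270-fold lower number from compound 2 to compound 3 (2.44 log units; beyond the scatter). Compound 2 reads > 25000 nM, which is a limit and not a number, so the full size of this step stays open: the limit of > 25000 nM in this assay, at which 2 of the 3 values shown sit.

Going by these compounds alone, compound 3 is the only compound of the three with a value that is a number, which the two earlier limits gave no sign of.

Within the data shown here, the single pair does not show which part of methoxycarbonyl carries the step; a carboxylic acid, a primary amide or a longer ester such as ethoxycarbonyl at the same place would separate these. Also open, from the compounds shown here alone, is whether the step holds when a cyclic amine replaces the amine of the shared core.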